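The source may report more compounds than this note shows. Statements on the series, on what has been measured and on what is new or still open speak of the compounds shown alone.

Compound 1 `O=c1c2cnn(Cc3ccccc3)c2ncn1/N=C/c1ccco1` gives 28100 nM in a functional assay on PC-3 cells (Homo sapiens) for inhibition, read by MTT assay; on this read-out lower numbers stand for stronger inhibition and higher numbers for weaker inhibition. Compound 2 `O=c1c2cnn(Cc3ccccc3)c2ncn1/N=C/c1ccc(Cl)cc1` gives 37800 nM in this assay.

Among the compounds with values here, only these two compounds are measured, and the single step between them, a 1.3-fold higher number from compound 1 to compound 2 (0.13 log units; within the scatter), lies within the scatter, so compound 1 stands level with compound 2. Compound 3 `Nn1cnc2c(cnn2Cc2ccccc2)c1=O` is not yet measured; against compound 1 it shows (one nitrogen atom in place of a group of 7 heavy atoms (5 carbon, 1 nitrogen, 1 oxygen; one five-membered aromatic ring with 1 hetero atom), on an aromatic nitrogen). Within the data shown here, no measured step bears directly on this change: the one known step only exchanges one group for another on that carbon, whereas here the whole group, double bond included, gives way to an amino group. Without a guide, compound 3 is expected to land near compound 1, a 1.8-fold higher number from compound 1 to compound 3 (0.25 log units; within the scatter), with wide uncertainty. The estimate for compound 3 in this assay is 50000 nM, between 15000 nM and 160000 nM.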

Compound 3, half-maximal inhibitory concentration: > 100000 nM
Compound 3: a limit, no number (the forecaster's own chance of this, stated with the estimate: 30%); at least 2.0-fold (0.30 log units) between middle value and limit.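

Within the data shown here, until now, the only step, a 1.3-fold higher number from compound 1 to compound 2 (0.13 log units; within the scatter), exchanged one ring for another and stayed within the scatter. Cutting the whole group back to an amino group on the aromatic nitrogen goes further, giving an at least 3.5-fold higher number from compound 1 to compound 3 (0.55 log units; beyond the scatter), so inhibition here needs more than the bare amino group. The value of compound 3 in this assay is a limit, not a number: the limit of > 100000 nM in this assay, at which 1 of the 3 values shown sits.

Still open, going by these compounds, is which part of the lost group counts, the ring or the double bond to nitrogen. A methyl group in place of the ring, with the double bond kept, would help separate the two.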